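Hydrogen in Place of Methyl on Sulfur

The compounds below may be only part of what the source reports. "The series", "measured", "known", "first", "only" and "open" are said of these compounds alone.

Compound 3 `COc1ccc(CNc2nc(SC)nc3ccccc23)cc1` was tested in a functional assay on HTB-54 cells (Homo sapiens) for cytotoxicity, read by MTT assay, with a stated time of 72 h; a lower number here means a stronger inhibitor of growth, a higher number a weaker inhibitor of growth. In this assay compound 3 gives only a limit, > 100000 nM. Compound 1 `COc1ccc(CNc2nc([SeH])nc3ccccc23)cc1` gives 60900 nM in this assay. Compound 2 `Sc1nc(NCc2ccccc2)c2ccccc2n1` likewise gives only a limit, > 100000 nM. Within the data shown here, the single measured step, an at least 1.6-fold higher number from compound 1 to compound 3 (0.21 log units; that floor lies within the scatter), is bounded by the limit of > 100000 nM in this assay, at which 2 of the 3 values shown sit, and so has no firm size. Compound 4 `COc1ccc(CNc2nc(S)nc3ccccc23)cc1` differs from compound 3 by hydrogen in place of methyl on a sulfur. Among the measured compounds shown here, no measured step covers this exact change. A step beyond the scatter is therefore not expected. Compound 4 is expected to show a number no higher from compound 3 to compound 4 (the limit leaves the size open) in this assay. Compound 4 is estimated at 100000 nM in this assay, within a range from 40000 nM to 300000 nM, most likely reported once more as a limit.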

Compound 4, concentration for total growth inhibition: 45500 nM
Compound 4: the middle estimate sits 2.2-fold (0.34 log units) above what was measured, and the stated range covers the measured number.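

In this assay, swapping methylsulfanyl for sulfanyl turns a limit into a firm number, a change beyond the usual scatter (an at least 2.1-fold lower number from compound 3 to compound 4 (0.34 log units; beyond the scatter)). Methoxy in place of hydrogen on an aromatic carbon also gives a step beyond the scatter (an at least 2.1-fold lower number from compound 2 to compound 4 (0.34 log units; beyond the scatter)). One sulfur atom in place of one selenium atom leaves the two compounds within the scatter of each other (a 1.3-fold lower number from compound 1 to compound 4 (0.13 log units; within the scatter)).

From the compounds shown here alone, the true size of the first two steps stays open because each starts from a limit: the limit of > 100000 nM in this assay, at which 2 of the 4 values shown sit. Going by these compounds, how an amine, a hydroxyl or a longer chain such as ethylsulfanyl would fare at this place remains open.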